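The source may hold more compounds than are shown below. What is called first, only, known or untested is meant among the compounds shown, and "the series" means these compounds.

Compound 1 `O=C(Nc1cc(Cl)cc(Cl)c1)c1cnc(Cl)nc1C(F)(F)F`, 500 nM; compound 2 `O=C(Nc1cc(Cl)cc(Cl)c1)c1cnc(O)nc1C(F)(F)F`, > 10000 nM; compound 3 `NC(=O)c1cc(NC(=O)c2cnc(Cl)nc2C(F)(F)F)cc(C(F)(F)F)c1`, 5000 nM.

In an assay on Jurkat cells for inhibition of nuclear factor NF-kappa-B p105 subunit (Homo sapiens) (a higher number here means a weaker inhibitor, a lower number a stronger inhibitor), compound 1 gives 500 nM. Compound 2 reaches only the assay limit, > 10000 nM, which is a limit and not a number (the limit of > 10000 nM in this assay, at which 1 of the 3 values shown sits). Compound 3 gives 5000 nM and thus stands highest of the two numbers, a weaker inhibitor than compound 1. Compound 4 `CCCCCCOC(=O)c1cc(NC(=O)c2cnc(Cl)nc2C(F)(F)F)cc(C(F)(F)F)c1` differs from compound 3 by hexyloxy in place of amino on a carbonyl carbon, carbamoyl to hexyloxycarbonyl. Going by the values given here, the one measured step, an at least 20-fold higher number from compound 1 to compound 2 (1.30 log units; beyond the scatter), sits on the shared core and not at the carbonyl carbon, so no measured step bears on this change. The expectation for compound 4 is a step of a 1.3-fold lower number from compound 3 to compound 4 (0.10 log units; within the scatter), a number near that of compound 3. Compound 4 is estimated at 4000 nM, within 1000 nM to 15000 nM.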

Compound 4, half-maximal inhibitory concentration: 620 nM
Compound 4: middle estimate off by 6.5-fold (0.81 log units), on the high side, outside the stated range (below it).
By their numbers in this assay, from the lowest: compounds 1 and 4 (each within the scatter of the next); then compound 3. At a limit, above all of these: compound 2.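

At this carbonyl carbon the group matters: in this assay, hexyloxy in place of amino gives an 8.1-fold lower number from compound 3 to compound 4 (0.91 log units; beyond the scatter) and so a stronger inhibitor. Going by these compounds alone, this is the first step read at this place, and it shows that carbamoyl is not needed here for inhibition. No information given here on these compounds accounts for the size of this step.

Open, from the compounds shown here alone, is whether the oxygen link or the length of the chain carries the step. A methoxy group, a carboxylic acid or a hexylamino group on the same carbonyl carbon would separate the two.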